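Trading a Methyl for Hydrogen on the Phenol Oxygen

The compounds below may be only part of what the source reports. "The series", "measured", "known", "first", "only" and "open" are said of these compounds alone.

Compound 3 `COc1cc(-c2nn(-c3cccc(NC(=O)Nc4cccc(C(F)(F)F)c4)c3)cc2-c2ccncc2)ccc1Cl` is one of a small set of diaryl ureas examined in a functional assay on HCT-15 cells (Homo sapiens) for inhibition, read by sulforhodamine B assay, with a stated time of 48 h; a higher number here means that more compound is tolerated, a lower number that less compound is tolerated. In this assay compound 3 gives 50000 nM. Of the two numbers available, that of compound 3 is the highest; its nearest neighbour, compound 2 `O=C(Nc1cccc(-n2cc(-c3ccncc3)c(-c3ccc(Cl)c(O)c3)n2)c1)Nc1cc(C(F)(F)F)cc(C(F)(F)F)c1`, gives 21200 nM, and the gap between them lies beyond the usual scatter. Compound 1 `O=C(Nc1cccc(-n2cc(-c3ccncc3)c(-c3ccc(Cl)c(O)c3)n2)c1)Nc1ccc(Cl)c(Cl)c1` reaches only a limit of the assay, > 32500 nM, so no number is known for it.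

The next compound, compound 4 `O=C(Nc1cccc(-n2cc(-c3ccncc3)c(-c3ccc(Cl)c(O)c3)n2)c1)Nc1cccc(C(F)(F)F)c1`, keeps the whole framework of compound 3 and differs from it in one place: hydrogen in place of methyl on an oxygen on an aromatic ring. Among the measured compounds shown here, no pair of measured compounds shows this same change, so the size of its effect cannot be read from an earlier step. Compound 2 already carries the hydroxy group, but it also differs in the other aryl ring, so its value speaks only for itself.

With nothing in the measured set pointing to a direction, the step from compound 3 to compound 4 is expected to be small, a 1.4-fold lower number from compound 3 to compound 4 (0.15 log units; within the scatter), staying within the scatter. Compound 4 is therefore estimated at 35000 nM, with a range from 12000 nM to 100000 nM.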

Compound 4, concentration lethal to 50% of the cells: > 32500 nM
Compound 4: no number, only a limit (the forecaster's own chance of this, stated with the estimate: 45%); the middle value lies beyond the limit too.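

In this assay compound 4 stops at a limit of the assay, > 32500 nM, which is not a number, and compound 1 stops at that same limit: the limit of > 32500 nM in this assay, at which 2 of the 4 values shown sit.

For the first time, methoxy to hydroxy on the 4-chloro-3-methoxyphenyl ring can be looked at as a single change, yet neither this step nor the step from compound 1 can be read, so the hydroxy compound is not shown to differ from its methoxy partner in either direction. Only the change on the other aryl ring gives a size, an at least 1.5-fold higher number from compound 2 to compound 4 (0.18 log units; that floor lies within the scatter), and as this is only a floor, the true step for hydrogen in place of trifluoromethyl could be small or larger.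

Going by these compounds, the size of the methoxy to hydroxy step stays open as long as compound 4 has a limit rather than a number. Also open, on these data alone, is what a different group on this oxygen would do, such as an ethyl group, a longer chain or a chain ending in an amine.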